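Replacing chloro with hydroxy in a cytotoxic series

The source may report more compounds than this note shows. Statements on the series, on what has been measured and on what is new or still open speak of the compounds shown alone.

Measured in a functional assay on MCF7 cells (Homo sapiens) for cytotoxicity, read by MTT assay, with a stated time of 72 h; a lower number here means a stronger inhibitor, a higher number a weaker inhibitor:
- compound 1 `COc1cccc(/C=C2\CCC/C(=C\c3cccc(O)c3)C2=O)c1OC`: 8800 nM
- compound 2 `COc1ccc(/C=C2\CCC/C(=C\c3cccc(Cl)c3)C2=O)cc1OC`: 6000 nM

Compound 2, at 6000 nM, lies within the usual scatter of compound 1, at 8800 nM. Compound 3 `COc1ccc(/C=C2\CCC/C(=C\c3cccc(O)c3)C2=O)cc1OC` has hydroxy in place of chloro on an aromatic carbon, turning 3-chlorophenyl into 3-hydroxyphenyl: hydroxy in place of chloro on an aromatic carbon. Among the measured compounds shown here, no measured pair differs in this one place alone. Compound 1 also carries the 3-hydroxyphenyl group, and compound 1 gives 8800 nM, so only a small change is expected. The expected step of a 1.1-fold higher number from compound 2 to compound 3 (0.03 log units; within the scatter) stays within the scatter in this assay. For compound 3 the estimated value is 6500 nM, with an expected range of 2500 nM to 17000 nM.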

Compound 3, half-maximal inhibitory concentration: 2900 nM
Compound 3: the middle estimate sits 2.2-fold (0.35 log units) above what was measured; low and high end bracket the measured number.
By their numbers in this assay, from the lowest: compound 3; then compounds 2 and 1 (each within the scatter of the next).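

In this assay, among the compounds shown here, turning 3-chlorophenyl into 3-hydroxyphenyl gives a 2.1-fold lower number from compound 2 to compound 3 (0.32 log units; beyond the scatter), the first comparison here in which only one place differs. This shows that the group at this position can shift the cytotoxicity reading on its own, and that hydroxy in place of chloro is tolerated and modestly favourable on this core. The result rests on a single pair, however, so it describes this core alone.

On these data alone, whether an amine, a carboxylic acid or a longer chain at this place would go further remains open. Nothing available explains why hydroxy gives the lower number.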